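Indole amide growth inhibitors: methyl to isopropyl

The compounds below may be only part of what the source reports. "The series", "measured", "known", "first", "only" and "open" are said of these compounds alone.

Of the compounds shown here, three sharing one core have been measured in a functional assay on NCI-H1975 cells (Homo sapiens) for antiproliferative activity, read by CCK-8 assay, with a stated time of 72 h; a lower number here means a stronger inhibitor of growth, a higher number a weaker inhibitor of growth. Compound 1 `CC[C@@H]1C(=O)N(C)c2cnc(Nc3ccc(S(=O)(=O)NC4CCCC4)cc3)nc2N1C1CCCC1` gives 1710 nM in this assay. Compound 3 `CCC1C(=O)N(C)c2cnc(Nc3ccc(S(=O)(=O)NCC(C)C)cc3)nc2N1c1ccn(C)n1` gives 15000 nM. Compound 2 `CCC1C(=O)N(C)c2cnc(-n3ccc4cc(C(=O)NC)ccc43)nc2N1c1ccn(C)n1` gives 35700 nM, the highest of the three numbers, so it is the weakest growth inhibitor of the set; the gap to compound 3 is beyond the scatter, and the gap to compound 1 is far beyond it. The three compounds differ from one another in more than one place, so none of these gaps can be tied to a single structural change.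

Compound 4 `CCC1C(=O)N(C)c2cnc(-n3ccc4cc(C(=O)NC(C)C)ccc43)nc2N1c1ccn(C)n1` is a close relative of compound 2 that has not yet been measured. The difference between the two is isopropyl in place of methyl on an amide-type nitrogen. Among the compounds with values here, no pair among the measured compounds shows what such a change does in this assay, so there is no direct guide for the size or direction of the step.

In the absence of such a guide, the step from compound 2 to compound 4 is expected to be small, and most likely none beyond the scatter, as a 1.2-fold lower number from compound 2 to compound 4 (0.08 log units; within the scatter). Compound 4 is therefore estimated to give about 30000 nM in this assay, with a range from 12000 nM to 80000 nM.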

Compound 4, concentration for 50% growth inhibition: 12200 nM
Estimate against measurement, compound 4: 2.5-fold (0.39 log units) above, within the range that was stated.
By their numbers in this assay, from the lowest: compound 1; then compounds 4 and 3 (each within the scatter of the next); then compound 2.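

In this assay, within the data shown here, this pair gives the first direct reading at this position: isopropyl in place of methyl on an amide-type nitrogen, whose other neighbour is the carbonyl carbon, brings a 2.9-fold lower number from compound 2 to compound 4 (0.47 log units; beyond the scatter) in the read-out. The step is modest but beyond the scatter, so the group on this nitrogen does affect growth inhibition, and the larger of these two groups is the better one here. No measurement at hand bears on the reason for this step.

From the compounds shown here alone, two groups at one nitrogen do not make a trend, so it remains open whether a longer chain such as n-butyl, or a ring such as cyclopropyl, would lower the number further or raise it again, and whether a second methyl on the same nitrogen, which would replace the amide hydrogen, would be tolerated. Going by these compounds, it also remains open whether isopropyl in place of methyl would give a step of similar size if other parts of the shared core were changed.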